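Compound 4: trifluoromethyl in place of fluoro

The compounds below may be only part of what the source reports. "The series", "measured", "known", "first", "only" and "open" are said of these compounds alone.

Compound 2 `COc1ccc(C(=O)/C=C/c2cccc(F)c2)c2c1C=CC(C)(C)O2` gives > 10000 nM in a functional assay on HT-29 cells (Homo sapiens) for antiproliferative activity, read by MTT assay, with a stated time of 24 h (on this read-out lower numbers stand for stronger inhibition and higher numbers for weaker inhibition), and this is a limit, not a number. Compound 1 `COc1ccc(/C=C/C(=O)c2ccc(OC)c3c2OC(C)(C)C=C3)c(F)c1` gives > 10000 nM, also a limit. Compound 3 `COc1ccc(/C=C/C(=O)c2ccc(OC)c3c2OC(C)(C)C=C3)cn1` gives > 10000 nM, again a limit. Going by the values given here, the series so far therefore shows (the limit of > 10000 nM in this assay, at which 3 of the 3 values shown sit).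

Compound 4 `COc1ccc(C(=O)/C=C/c2cccc(C(F)(F)F)c2)c2c1C=CC(C)(C)O2` carries trifluoromethyl in place of fluoro on an aromatic carbon of compound 2 (trifluoromethyl in place of fluoro on an aromatic carbon). The nearest evidence is a step that the two limits leave unreadable from compound 1 to compound 2, a step that the two limits leave unreadable from compound 1 to compound 3 and a step that the two limits leave unreadable from compound 2 to compound 3, none of which gives a size or direction. No step beyond the scatter can be supported, so the expectation is a step that the limit leaves unreadable from compound 2 to compound 4, with no direction favoured. For compound 4 the estimated value in this assay is 12000 nM, with an expected range of 5000 nM to 30000 nM.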

Compound 4, half-maximal inhibitory concentration: 9050 nM
The estimate for compound 4 lay 1.3-fold (0.12 log units) above the measured number; measured number inside the range.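

Going by these compounds alone, compound 4 is the first compound here to give a number rather than a limit in this assay, with trifluoromethyl on an aromatic carbon, meta to a large group. Within the data shown here, with an at least 1.1-fold lower number from compound 2 to compound 4 (0.04 log units; that floor lies within the scatter) as the only readable step, nothing shows that trifluoromethyl differs from fluoro at this position. The other steps cannot be read, and most of the series remains at the limit: the limit of > 10000 nM in this assay, at which 3 of the 4 values shown sit.

Going by these compounds, it remains open whether a nitrile or an amine on this carbon would give a clearly lower number. On these data alone, whether trifluoromethyl would give a readable value on the other aryl groups also remains open.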